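Working notes: chloro step on compound 3

The source may report more compounds than this note shows. Statements on the series, on what has been measured and on what is new or still open speak of the compounds shown alone.

Measured so far in a functional assay on OVCAR-8 cells (Homo sapiens) for inhibition, with a stated time of 48 h (on this read-out higher numbers stand for weaker inhibition of growth and lower numbers for stronger inhibition of growth), for three compounds:
- compound 1 `COc1ccccc1/C=C/C(=O)c1c(O)cc2occc2c1OC` gives 53800 nM
- compound 2 `COc1c(C(=O)/C=C/c2ccc(Cl)cc2)c(O)c(Br)c2occc12` gives 3430 nM
- compound 3 `C=CCc1c(O)c(C(=O)/C=C/c2ccccc2)c(OC)c2ccoc12` gives 3130 nM

Compound 3 lies within the scatter of compound 2, and its number is lower than that of compound 1 by more than the scatter. Compound 4 `C=CCc1c(O)c(C(=O)/C=C/c2ccc(Cl)cc2)c(OC)c2ccoc12` follows from compound 3 by one change (chloro in place of hydrogen on an aromatic carbon), chloro in place of hydrogen on an aromatic carbon, para to a large group. For the measured compounds named here, no measured pair isolates this change. Compound 2 carries the same 4-chlorophenyl and gives 3430 nM but differs elsewhere too, so it is only a loose guide. No step beyond the scatter is expected in this assay in either direction. The estimated step (a 1.1-fold lower number from compound 3 to compound 4 (0.05 log units; within the scatter)) stays small. For compound 4 the expected value is 2800 nM (range 1100 nM to 7000 nM).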

Compound 4, concentration for 50% growth inhibition: 3040 nM
Compound 4: middle estimate off by 1.1-fold (0.04 log units), on the low side; the measured number falls inside the stated range.
By their numbers in this assay, from the lowest: compounds 4, 3 and 2 (each within the scatter of the next); then compound 1.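

For the compounds shown here, the first direct pair at this position shows that phenyl to 4-chlorophenyl, on an aromatic carbon para to a large group, gives no step beyond the scatter in this assay (a 1.0-fold lower number from compound 3 to compound 4 (0.01 log units; within the scatter)). With the 4-chlorophenyl held fixed, allyl in place of bromo on an aromatic carbon also stays within the scatter (a 1.1-fold lower number from compound 2 to compound 4 (0.05 log units; within the scatter)). No other data bear on these two results.

On these data alone, whether an amine or a carboxylic acid in place of the chloro would give a step beyond the scatter remains open. The same holds for a longer chain in place of the allyl.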